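The compounds below may be only part of what the source reports. "The series", "measured", "known", "first", "only" and "open" are said of these compounds alone.

In a functional assay on A549 cells (Homo sapiens) for antiproliferative activity, read by sulforhodamine B assay, with a stated time of 3 days (a higher number here means a weaker inhibitor of growth, a lower number a stronger inhibitor of growth), two amides on a shared core have been measured so far. Compound 1 (`O=C(Nc1cccc(Nc2ncc(F)c(Nc3ccc(F)cc3)n2)c1)c1cccc([N+](=O)[O-])c1`) gives 7250 nM, and compound 2 (`O=C(Nc1cccc(Nc2ncc(F)c(Nc3ccc(F)cc3)n2)c1)c1ccncc1`) gives 1650 nM, the lower of the two numbers. Compound 3 (`CN(C)CC(=O)Nc1cccc(Nc2ncc(F)c(Nc3ccc(F)cc3)n2)c1`) keeps the core of compound 2 and differs only on the carbonyl carbon, where (dimethylamino)methyl stands in place of pyridin-4-yl: (dimethylamino)methyl in place of pyridin-4-yl on a carbonyl carbon. Within the data shown here, one measured step bears on this place, a 4.4-fold lower number from compound 1 to compound 2 (0.64 log units; beyond the scatter), a modest change beyond the scatter. It bears only loosely, as it exchanges one ring for another, whereas here the ring leaves and an open chain enters. Among the measured compounds shown here, no compound without a ring on that carbonyl carbon has been measured, so the direction is poorly defined. A change of about that modest size remains possible either way, with a slight lean towards a higher number. The expected result is therefore a small move that may not clear the scatter. The estimated change is a 1.5-fold higher number from compound 2 to compound 3 (0.18 log units; within the scatter). For compound 3, the estimated value is 2500 nM, with an expected range of 700 nM to 9000 nM.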

Compound 3, concentration for 50% growth inhibition: 1180 nM
Compound 3: middle estimate off by 2.1-fold (0.33 log units), on the high side, within the range that was stated.
By their numbers in this assay, from the lowest: compounds 3 and 2 (each within the scatter of the next); then compound 1.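

In this assay, an open chain on the carbonyl carbon, (dimethylamino)methyl, replaces the ring of compound 2 with a 1.4-fold lower number from compound 2 to compound 3 (0.15 log units; within the scatter), so among these compounds a ring at this place is not needed to reach the level of compound 2. The same chain in place of 3-nitrophenyl gives a 6.1-fold lower number from compound 1 to compound 3 (0.79 log units; beyond the scatter), which shows that compound 1 stands apart from both compound 2 and compound 3, whether a ring or an open chain takes the place of 3-nitrophenyl. Nothing given here accounts for these numbers, and the reason for them stays unexplained.

Going by these compounds, it remains open whether the nitrogen of the chain contributes at all, a question that a plain methyl group on the same carbonyl carbon would address. A longer chain ending in dimethylamino, or a morpholine ring, would show how far this place tolerates other amines, and an unsubstituted phenyl ring would show whether the number of compound 1 belongs to the nitro group or to the benzene ring that carries it.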